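The compounds below may be only part of what the source reports. "The series", "measured", "known", "first", "only" and "open" are said of these compounds alone.

In an in vivo ADME assay on the whole organism (strain BALB/C) for pharmacokinetics, with Mus musculus as the target, read by LC-MS, at a dose of 10 mg/kg by the oral route (a higher number here means that a larger share of the oral dose reaches the circulation, a lower number that a smaller share of the oral dose reaches the circulation), the series stands so:
- compound 1 `CN1C[C@H](C(=O)Nc2ccc(F)c(F)c2)[C@@H](c2ccc(/C=C/C(=O)Nc3ccccc3N)cc2)C1` gives 29%
- compound 2 `CC(C)N1C[C@H](C(=O)Nc2ccc(Cl)cc2)[C@@H](c2ccc(/C=C/C(=O)Nc3ccccc3N)cc2)C1` gives 100%
- compound 3 `CC(C)(C)N1C[C@H](C(=O)Nc2ccc(Cl)cc2)[C@@H](c2ccc(/C=C/C(=O)Nc3ccccc3N)cc2)C1` gives 59%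

Compound 3 is second highest of the three, below compound 2 and above compound 1, with both gaps beyond the scatter. Compound 4 `CC(C)(CO)N1C[C@H](C(=O)Nc2ccc(Cl)cc2)[C@@H](c2ccc(/C=C/C(=O)Nc3ccccc3N)cc2)C1` carries one change from it, (hydroxy in place of hydrogen on a saturated chain carbon, two bonds along the chain from an amine nitrogen in a ring), turning tert-butyl into 1-(hydroxymethyl)-1-methylethyl. Among the measured compounds shown here, only one measured step touches this group, a number 41 percentage points lower from compound 2 to compound 3 (beyond the scatter), and it was large. That step added a methyl, not a hydroxy, so it shows that the number can move here but fixes no direction for this change. A moderate fall is expected, with wide uncertainty, and the estimated move is a number 14 percentage points lower from compound 3 to compound 4 (beyond the scatter). For compound 4 the estimated value is 45%, with an expected range of 20% to 75%.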

Compound 4, oral bioavailability: 12%
Beside the measured number, compound 4's estimate is 33 percentage points above it; measured number below the stated range.
By their numbers in this assay, from the lowest: compound 4; then compound 1; then compound 3; then compound 2.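

In this assay, the hydroxy placed on a saturated chain carbon, two bonds along the chain from an amine nitrogen in a ring, gives a number 47 percentage points lower from compound 3 to compound 4 (beyond the scatter) and shows that this position responds to more than methyl. Set against the isopropyl compound, the hydroxymethyl gives a number 88 percentage points lower from compound 2 to compound 4 (beyond the scatter) in the same direction as a number 41 percentage points lower from compound 2 to compound 3 (beyond the scatter) for methyl. Nothing shown explains either fall.

Open, from the compounds shown here alone, is whether a methoxy or an amine at this carbon would fall as far. Also open, going by these compounds, is whether a hydroxy on a longer chain would follow compound 4.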